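This account rests on a few compounds, and the source may have more. Where it says the series, first, only, none or still open, it means among the compounds named here.

Measured so far in an ADME assay on HepG2 cells (Homo sapiens) for cytotoxicity, read by MTT assay, with a stated time of 72 h; a higher number here means that more compound is tolerated, a lower number that less compound is tolerated:
- compound 1 `O=[N+]([O-])c1c(CS(=O)(=O)c2ccccc2)nc2c(-c3ccccc3)cc(Cl)cn12` gives > 15600 nM
- compound 2 `O=[N+]([O-])c1c(CS(=O)(=O)c2ccccc2)nc2c(-c3ccc(O)cc3)cc(Cl)cn12` gives > 12500 nM
- compound 3 `O=[N+]([O-])c1c(CS(=O)(=O)c2ccccc2)nc2c(-c3ccc(CO)cc3)cc(Cl)cn12` gives 13100 nM

The value for compound 1 is a limit and not a number. The value for compound 2 is likewise only a limit. Compound 3, at 13100 nM, is thus the only one of the three with a true number.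

Compound 4 `O=[N+]([O-])c1c(CS(=O)(=O)c2ccccc2)nc2c(-c3ccc(F)cc3F)cc(Cl)cn12` carries 2,4-difluorophenyl in place of 4-(hydroxymethyl)phenyl on an aromatic carbon. Two measured steps give no size: a step that the two limits leave unreadable from compound 1 to compound 2 and a step that the limit leaves unreadable from compound 2 to compound 3. The third, an at least 1.1-fold lower number from compound 1 to compound 3 (0.07 log units; that floor lies within the scatter), is the only one with a readable size, so no step beyond the scatter is expected in this assay for this exchange. The estimate amounts to an expected 1.1-fold higher number from compound 3 to compound 4 (0.03 log units; within the scatter). For compound 4 the expected value is 14000 nM, with an estimated range from 7000 nM to 28000 nM.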

Compound 4, half-maximal cytotoxic concentration: > 7800 nM
Compound 4 gave a limit, no number; the forecaster's own chance of this, stated with the estimate: 65%; the middle value is on the limit's open side.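

In this assay compound 4 gives > 7800 nM, a limit and not a number. Within the data shown here, no step from compound 1, compound 2 or compound 3 to compound 4 can be read. The compounds shown leave open whether 2,4-difluorophenyl in compound 4 changes the number in this assay at all.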